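The compounds below may be only part of what the source reports. "The series", "measured", "known", "first", "only" and "open" are said of these compounds alone.

Values measured in a functional assay on cells (Platelet, Homo sapiens) for inhibition (a higher number here means a weaker inhibitor, a lower number a stronger inhibitor), follow.
Compound 1 `CCOC(=O)c1ccc(-c2nn(C)c3ccccc23)cc1` gives > 10000 nM
Compound 2 `CCOC(=O)c1ccc(-c2nn(Cc3ccccc3OC)c3ccccc23)cc1` gives > 10000 nM
Compound 3 `CCOC(=O)c1cccc(-c2nn(Cc3ccccc3)c3ccccc23)c1` gives > 10000 nM

Compound 2 stands at > 10000 nM in this assay, which is a limit of the assay and not a number. The same holds across the series, with the limit of > 10000 nM in this assay, at which 3 of the 3 values shown sit, as the whole record so far.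

Compound 4 `CCOC(=O)c1ccc(-c2nn(-c3ccoc3)c3ccccc23)cc1` has furan-3-yl in place of 2-methoxybenzyl on an aromatic nitrogen, and furan-3-yl in place of 2-methoxybenzyl on an aromatic nitrogen gives the full count of that change. Among the measured compounds shown here, the one measured step that touches this group is a step that the two limits leave unreadable from compound 1 to compound 2, so it offers no size to carry over. With no readable step as a guide, no shift in either direction is expected in this assay, and another reported limit is the likeliest result.

The expected step is a step that the limit leaves unreadable from compound 2 to compound 4 and it rests on very little. For compound 4 the estimated value is 15000 nM as a rough figure. The estimated range for compound 4 runs from 6000 nM to 40000 nM in this assay.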

Compound 4, half-maximal inhibitory concentration: > 10000 nM
Compound 4: no number, only a limit; the forecaster's own chance of this, stated with the estimate: 80%; the middle value lies beyond the limit too.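

In this assay compound 4 gives > 10000 nM, which is a limit of the assay and not a number. Its steps from compound 1 and compound 2 therefore cannot be read. The compounds shown leave open which change to the shared core, if any, would give a measurable value in this assay.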